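Swapping phenyl for pyridin-4-yl: expected cytotoxicity of compound 4

A few compounds are considered here, and "the series" means these few. Any claim that something is new, unique, unknown or untested is made for them only; others in the source may bear on it.

Measured so far in an ADME assay on MT4 cells (Homo sapiens) for cytotoxicity, read by MTT assay, with a stated time of 5 days; on this read-out higher numbers stand for lower toxicity in this test and lower numbers for higher toxicity in this test:
Compound 1 `Cc1cc(C#N)cc(C)c1Oc1nc(Nc2ccc(C#N)cc2)ncc1-c1ccccc1` gives 31800 nM.
Compound 2 `Cc1cc(C#N)cc(C)c1Oc1nc(Nc2ccc(C#N)cc2)ncc1-c1ccc(-c2ccccc2)cc1` is reported only as a limit, > 253000 nM.
Compound 3 `Cc1cc(C#N)cc(C)c1Oc1nc(Nc2ccc(C#N)cc2)ncc1-c1cccs1` gives 6430 nM.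

Compound 1 has the highest number among the two numbers shown, with compound 3 nearest, a 4.9-fold lower number from compound 1 to compound 3 (0.69 log units; beyond the scatter). Compound 4 `Cc1cc(C#N)cc(C)c1Oc1nc(Nc2ccc(C#N)cc2)ncc1-c1ccncc1` differs from compound 1 by pyridin-4-yl in place of phenyl on an aromatic carbon. Within the data shown here, two measured steps touch the same position: replacing phenyl with thiophen-2-yl gave a 4.9-fold lower number from compound 1 to compound 3 (0.69 log units; beyond the scatter), and adding phenyl gave an at least 7.9-fold higher number from compound 1 to compound 2 (0.90 log units; beyond the scatter), though that value is only a limit (the limit of > 253000 nM in this assay, at which 1 of the 3 values shown sits). Neither step matches the present change, so only a small shift is expected. Compound 4 is expected at 40000 nM, between 12000 nM and 130000 nM, meaning a 1.3-fold higher number from compound 1 to compound 4 (0.10 log units; within the scatter).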

Compound 4, half-maximal cytotoxic concentration: 28000 nM
Beside the measured number, compound 4's estimate is 1.4-fold (0.15 log units) above it; the measured number falls inside the stated range.
By their numbers in this assay, from the lowest: compound 3; then compounds 4 and 1 (each within the scatter of the next). At a limit, above all of these: compound 2.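

In this assay, the new ring nitrogen leaves pyridin-4-yl indistinguishable from phenyl at this carbon, with a 1.1-fold lower number from compound 1 to compound 4 (0.06 log units; within the scatter). Pyridin-4-yl in place of thiophen-2-yl gives a 4.4-fold higher number from compound 3 to compound 4 (0.64 log units; beyond the scatter), so the lower number of compound 3 is not shared by compound 4. Pyridin-4-yl in place of 4-phenylphenyl gives an at least 9.0-fold lower number from compound 2 to compound 4 (0.95 log units; beyond the scatter), a step read from a limit: the limit of > 253000 nM in this assay, at which 1 of the 4 values shown sits.

Still open, going by these compounds, is whether moving the ring nitrogen, as in pyridin-3-yl, would give the same result. Also open, on these data alone, is how a non-aromatic group, such as morpholine or a simple amine, would read at this carbon.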